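A few compounds are considered here, and "the series" means these few. Any claim that something is new, unique, unknown or untested is made for them only; others in the source may bear on it.

Measured so far in a functional assay on SH-SY5Y cells (Homo sapiens) for cytotoxicity, read by MTT assay, with stated times of 8 h, 30 min and 12 h, tested at 0.5 uM; on this read-out lower numbers stand for a weaker effect and higher numbers for a stronger effect at the one concentration tested:

compound 1 `COc1ccc(CNC(=N)[C@@H]2CCC(=O)N2Cc2ccccc2)cc1` gives 23.6%
compound 2 `COc1ccc(CNC(=N)[C@@H]2CCC(=O)N2Cc2ccccc2[N+](=O)[O-])cc1` gives 21.1%
compound 3 `N=C(NCc1ccc(O)cc1)[C@@H]1CCC(=O)N1Cc1ccc(F)cc1` gives 42%

Compound 3 stands highest of the three numbers; its nearest neighbour is compound 1, whose number is lower beyond the scatter, and compound 2 lies further still. Compound 3 differs from compound 1 in two places at once, so its two values alone cannot tell which change carries the gap. Going by the values given here, the one single-point step in hand is a number 2.5 percentage points lower from compound 1 to compound 2 (within the scatter), a change that does not touch the part of the molecule altered here.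

Compound 4 `COc1ccc(CNC(=N)[C@@H]2CCC(=O)N2Cc2ccc(F)cc2)cc1` is compound 3 with one change: methyl in place of hydrogen on an oxygen on an aromatic ring Nothing measured bears directly on this step. What the shared core with a methoxy group shows is the pair of numbers for compound 1 and compound 2, both well under that of compound 3; what the fluorine-bearing benzyl group shows is compound 3 alone. The expected step in this assay is therefore downward, toward the methoxy-bearing pair, but with wide uncertainty since the two features have never been separated.

Compound 4 is expected to give 30%, between 15% and 48%, an estimated step of a number 12 percentage points lower from compound 3 to compound 4 (beyond the scatter).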

Compound 4, a percentage reported as activity, at one concentration (the size of the read-out at that concentration, not a potency): 36.7%
The estimate for compound 4 lay 6.7 percentage points below the measured number; measured number inside the range.
By their numbers in this assay, from the lowest: compounds 2 and 1 (each within the scatter of the next); then compounds 4 and 3 (each within the scatter of the next).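

In this assay, the change from 4-hydroxyphenyl to 4-methoxyphenyl gives a number 5.3 percentage points lower from compound 3 to compound 4 (within the scatter), so this read-out does not separate hydroxy from methoxy on this aromatic ring, and this oxygen substituent does not account for the wider gap seen earlier. With the methoxy group held fixed, a single added fluoro group gives a number 13.1 percentage points higher from compound 1 to compound 4 (beyond the scatter), and 4-fluorophenyl in place of 2-nitrophenyl gives a number 15.6 percentage points higher from compound 2 to compound 4 (beyond the scatter), so in these two comparisons the change on the other aromatic ring carries a step beyond the scatter, though each is a single pair and the first rests on this one fluoro placement. Nothing available gives a reason for either the flat step or the two larger ones.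

As far as these compounds go, it remains open whether a group other than hydroxy or methoxy at this oxygen-bearing place, such as an ethoxy group, an amine or a carboxylic acid, would also leave the number within the scatter. From the compounds shown here alone, it also remains open whether chloro or trifluoromethyl in place of fluoro would match the step seen with fluoro, and whether that step holds with hydroxy in place of methoxy.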